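This account rests on a few compounds, and the source may have more. Where it says the series, first, only, none or still open, it means among the compounds named here.

Compound 2 (`O=C(NO)c1ccc(CNCc2nc(-c3ccc([N+](=O)[O-])cc3)no2)cc1`) reads > 100000 nM in a functional assay on A549 cells (Homo sapiens) for inhibition, read by MTT assay, with a stated time of 72 h (a lower number here means a stronger inhibitor, a higher number a weaker inhibitor), a limit of the assay and not a number. Compound 3 (`O=C(NO)c1ccc(CNCc2nc(-c3ccc(F)cc3)no2)cc1`) has fluoro in place of nitro on an aromatic carbon, para to a large group: fluoro in place of nitro on an aromatic carbon. Going by the values given here, no measured step covers this change. Among the compounds with values here, the only numeric anchor is compound 1 (`Nc1ccccc1NC(=O)c1ccc(CNCc2nc(-c3ccc(F)cc3)no2)cc1`), which also carries the 4-fluorophenyl and gives 10700 nM in this assay. A modest shift towards stronger inhibition is expected, with the estimated move being an at least 2.5-fold lower number from compound 2 to compound 3 (0.39 log units; beyond the scatter). For compound 3 the estimated value is 40000 nM, with an expected range of 10000 nM to 100000 nM.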

Compound 3, half-maximal inhibitory concentration: > 100000 nM
Compound 3: a limit, no number (the forecaster's own chance of this, stated with the estimate: 35%); middle value at least 2.5-fold (0.39 log units) from the limit.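

In this assay compound 3 reads > 100000 nM, a limit of the assay and not a number. The change from 4-nitrophenyl to 4-fluorophenyl therefore cannot be read, as compound 2 and compound 3 both sit at this limit: the limit of > 100000 nM in this assay, at which 2 of the 3 values shown sit.

Going by these compounds alone, the one readable step, with 4-fluorophenyl held, is hydroxy in place of 2-aminophenyl on an amide-type nitrogen, giving an at least 9.3-fold higher number from compound 1 to compound 3 (0.97 log units; beyond the scatter).

Going by these compounds, whether this aromatic carbon affects the read-out at all remains open. Nitro or an amine there, with 2-aminophenyl on the amide-type nitrogen, would test this within the readable range.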